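Working notes on an adenosine-linked amine series, third step

The source may hold more compounds than are shown below. What is called first, only, known or untested is meant among the compounds shown, and "the series" means these compounds.

Measured compounds:
compound 1 `NC(=O)CCCCN(Cc1cccc(C(N)=O)c1)C[C@H]1O[C@@H](n2cnc3c(N)ncnc32)[C@H](O)[C@@H]1O` — in an assay on cells for inhibition of Nicotinamide N-methyltransferase (Homo sapiens), with stated times of 10 min and 30 min (a higher number here means a weaker inhibitor, a lower number a stronger inhibitor), compound 1 gives > 250000 nM, which is a limit of the assay and not a number.
compound 2 `NC(=O)c1cccc(CN(CCCC(=O)O)C[C@H]2O[C@@H](n3cnc4c(N)ncnc43)[C@H](O)[C@@H]2O)c1` — in this assay compound 2 gives > 250000 nM, again a limit of the assay.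
compound 3 `CC(C)N(Cc1cccc(C(N)=O)c1)C[C@H]1O[C@@H](n2cnc3c(N)ncnc32)[C@H](O)[C@@H]1O` — in this assay compound 3 gives > 250000 nM, also a limit of the assay.

Compound 3 therefore stands nowhere on a scale of numbers: its value is a limit, and so are the two others shown. The three steps among the measured compounds, a step that the two limits leave unreadable from compound 1 to compound 2, a step that the two limits leave unreadable from compound 1 to compound 3 and a step that the two limits leave unreadable from compound 2 to compound 3, all concern the group on the amine nitrogen and all remain unreadable, because of the limit of > 250000 nM in this assay, at which 3 of the 3 values shown sit.

Compound 4 `CC(C)N(Cc1ccc2ccccc2c1)C[C@H]1O[C@@H](n2cnc3c(N)ncnc32)[C@H](O)[C@@H]1O` differs from compound 3 at a different place, the substituted benzyl arm: naphthalen-2-yl in place of 3-carbamoylphenyl on a saturated chain carbon bound to an amine nitrogen. Among the compounds with values here, no measured step touches this part of the structure, and the steps that exist carry no readable size, so no direction or magnitude can be taken from them. With every value in the series sitting at the limit, the expectation for compound 4 in this assay is an estimated 200000 nM, with an expected range from 20000 nM to 250000 nM. The step this estimate implies, an at least 1.2-fold lower number from compound 3 to compound 4 (0.09 log units; that floor lies within the scatter), is expected to stay unreadable against the limit of compound 3.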

Compound 4, half-maximal inhibitory concentration: 130000 nM
For compound 4 the middle estimate is 1.5-fold (0.19 log units) above the measured one, within the range that was stated.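

In this assay, within the data shown here, compound 4 gives 130000 nM, the first value that is a number and not a limit of the assay. Compound 3 gives > 250000 nM, which is a limit of the assay. Among these compounds, at the substituted benzyl arm, naphthalen-2-yl in place of 3-carbamoylphenyl on a saturated chain carbon bound to an amine nitrogen gives an at least 1.9-fold lower number from compound 3 to compound 4 (0.28 log units; that floor lies within the scatter), so this is the first change with a readable size, though only as a floor, and the full size of the step stays unknown.

The steps among compound 1, compound 2 and compound 3 still cannot be read, and the group on the amine nitrogen therefore has no measured effect so far, because of the ceiling on the read-out: the limit of > 250000 nM in this assay, at which 3 of the 4 values shown sit. Open, as far as these compounds go, is whether the second aromatic ring of naphthalen-2-yl is what brings a readable value, which a plain phenyl or a 3-aminophenyl arm would test, and whether naphthalen-2-yl keeps a readable value with 3-carboxypropyl or 4-carbamoylbutyl in place of isopropyl on the amine nitrogen.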